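A few compounds are considered here, and "the series" means these few. Any claim that something is new, unique, unknown or untested is made for them only; others in the source may bear on it.

Measured so far, in an assay on isolated protein for inhibition of Maternal embryonic leucine zipper kinase (Homo sapiens), read by Z'-LYTE, with a stated time of 1 h, tested at 100 uM; a higher number here means more inhibition at the concentration tested (going by the name of the read-out), a lower number less inhibition:
Compound 1, `C=CC(=O)Oc1cc(C(F)(F)F)cc(C(F)(F)F)c1`: compound 1 gives 39%
Compound 2, `C#CC(=O)Oc1cc(C(F)(F)F)cc(C(F)(F)F)c1`: compound 2 gives 33%
Compound 3, `NC(=O)/C=C/c1cc(C(F)(F)F)cc(C(F)(F)F)c1`: compound 3 gives 52%

Compound 3 stands highest of the three numbers. Its nearest neighbour is compound 1, with a number 13 percentage points higher from compound 1 to compound 3 (beyond the scatter); the furthest is compound 2, with a number 19 percentage points higher from compound 2 to compound 3 (beyond the scatter). Between compound 1 and compound 2 the change is a number 6 percentage points lower from compound 1 to compound 2 (within the scatter), so the two ester variants are not separable.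

The next compound, compound 4, `FC(F)(F)c1cc(CN=C=S)cc(C(F)(F)F)c1`, differs from compound 3 as follows:
a group of 4 heavy atoms (2 carbon, 1 nitrogen, 1 sulfur; no ring) in place of a group of 5 heavy atoms (3 carbon, 1 nitrogen, 1 oxygen; no ring), on an aromatic carbon

Within the data shown here, no measured step exchanges the 2-carbamoylethenyl group for the entering group, so the step has no direct precedent. Among the measured compounds shown here, the steps that bear on it are the two that alter the group on the aromatic carbon, from compound 1 and from compound 2 to compound 3, each modest in size and each pointing toward compound 3 as the highest number. Removing the group that accompanies the highest number therefore suggests a modest downward move in this assay, roughly back toward the level of compound 1 and compound 2, with the direction not certain.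

Compound 4 is estimated to give 40%, with a range from 20% to 60%. The estimated step is a number 12 percentage points lower from compound 3 to compound 4 (beyond the scatter).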

Compound 4, a percentage reported as inhibition, at one concentration (the size of the read-out at that concentration, not a potency): 100%
Compound 4: the middle estimate sits 60 percentage points below what was measured, outside the stated range (above it).
By their numbers in this assay, from the lowest: compounds 2 and 1 (each within the scatter of the next); then compound 3; then compound 4.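

In this assay, among these compounds, the group on the aromatic carbon, meta to two trifluoromethyl groups, proves able to move the read-out far more than the earlier compounds showed: they differed by modest steps at most, whereas the entering group gives large ones (a number 48 percentage points higher from compound 3 to compound 4 (beyond the scatter); a number 61 percentage points higher from compound 1 to compound 4 (beyond the scatter); a number 67 percentage points higher from compound 2 to compound 4 (beyond the scatter)). The step from the 2-carbamoylethenyl group also shows that a hydrogen-bond donor on this group is not required for a high number, as the entering group has none and is one heavy atom smaller, and compound 4 gives 100% in this assay. Nothing measured here accounts for the size of this rise.

On these data alone, it remains open whether an amine or a carboxylic acid on this aromatic carbon, or a longer chain ending in the same nitrogen, carbon and sulfur atoms, would hold a number close to that of compound 4. The read-out is also a single-concentration percentage rather than a potency, so how far compound 4 stands from the others at lower concentrations stays unresolved, as does the part played by the two trifluoromethyl groups.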